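This account rests on a few compounds, and the source may have more. Where it says the series, first, only, none or still open, it means among the compounds named here.

Among the compounds with values here, compound 1 `Nc1cc(S(=O)(=O)c2ccccc2)c([N+](=O)[O-])c2cccnc12` is the only compound here with a measured number to its name: in an assay for binding affinity to Neuropeptide Y receptor type 1 (Homo sapiens), read by radioligand binding (a higher number here means a weaker inhibitor, a lower number a stronger inhibitor), compound 1 gives 297 nM. Compound 2 `Nc1ccc(S(=O)(=O)c2cc(N)c3ncccc3c2)cc1` gives > 10000 nM in this assay, which is a limit of the assay and not a number; it sits at the limit of > 10000 nM in this assay, at which 1 of the 2 values shown sits. Compound 3 `CCc1ccccc1S(=O)(=O)c1cc(N)c2ncccc2c1[N+](=O)[O-]` differs from compound 1 by ethyl in place of hydrogen on an aromatic carbon. Within the data shown here, no measured pair shows what such a change does. For the step from compound 1 to compound 3 no move beyond the scatter of this assay is expected, a 1.2-fold lower number from compound 1 to compound 3 (0.07 log units; within the scatter). Compound 3 is therefore estimated at 250 nM in this assay, within a range from 60 nM to 1000 nM.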

Compound 3, inhibition constant: 129 nM
Estimate against measurement, compound 3: 1.9-fold (0.29 log units) above, and the stated range covers the measured number.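

Going from phenyl to 2-ethylphenyl, on an aromatic carbon ortho to a large group, gives in this assay a 2.3-fold lower number from compound 1 to compound 3 (0.36 log units; beyond the scatter), a modest gain. Within the data shown here, this is the first step read at this position, and it shows that ethyl can replace hydrogen here without loss of binding. Nothing shown accounts for the size of this step.

Going by these compounds, whether methyl, a longer chain such as propyl, or an amine at this place would move the number further remains open. So does whether ethyl would give a similar step on another carbon of this ring.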